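Swapping a Hydroxy for an Ethoxycarbonyl on the Phenyl

The source may report more compounds than this note shows. Statements on the series, on what has been measured and on what is new or still open speak of the compounds shown alone.

Among the compounds with values here, compound 2 `Cc1cc2c(c(=O)[nH]1)C(=O)O/C2=C\c1ccc(CO)n1-c1ccc(O)cc1` gives 21700 nM in an assay on kidney for inhibition of tissue alpha-L-fucosidase (Bos taurus), read by spectrophotometry, with a stated time of 10 min (a lower number here means a stronger inhibitor, a higher number a weaker inhibitor), one of only two numbers measured so far. Compound 1 `Cc1cc2c(c(=O)[nH]1)C(=O)O/C2=C\c1ccc(CO)n1-c1ccccc1` gives 38400 nM in this assay, and a 1.8-fold lower number from compound 1 to compound 2 (0.25 log units; within the scatter). Compound 3 `CCOC(=O)c1ccc(-n2c(/C=C3\OC(=O)c4c3cc(C)[nH]c4=O)ccc2CO)cc1` differs from compound 2 by ethoxycarbonyl in place of hydroxy on an aromatic carbon, on an aromatic carbon of a six-membered aromatic ring of carbon only, para to a large group. Within the data shown here, the single measured step concerns a different change and stayed within the scatter, so no step beyond the scatter is expected in this assay. Compound 3 is estimated at 30000 nM, between 8000 nM and 110000 nM. The expected step is a 1.4-fold higher number from compound 2 to compound 3 (0.14 log units; within the scatter).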

Compound 3, half-maximal inhibitory concentration: 30400 nM
Compound 3: middle estimate off by 1.0-fold (0.01 log units), on the low side; the range from low to high includes it.
By their numbers in this assay, from the lowest: compounds 2, 3 and 1 (each within the scatter of the next).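

In this assay, this position, para to a large group, takes ethoxycarbonyl, with 5 heavy atoms where hydroxy has 1, with no step beyond the scatter (a 1.4-fold higher number from compound 2 to compound 3 (0.15 log units; within the scatter)). The same holds when ethoxycarbonyl replaces hydrogen (a 1.3-fold lower number from compound 1 to compound 3 (0.10 log units; within the scatter)), so hydrogen, hydroxy and ethoxycarbonyl here cannot be told apart in this assay. No measured evidence bears on this result. The compounds shown leave open whether a carboxylic acid, an amine or a longer chain at this position would produce a step beyond the scatter.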